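The compounds below may be only part of what the source reports. "The series", "measured", "known", "first", "only" and "open" are said of these compounds alone.

Measured in a functional assay on SK-OV-3 cells (Homo sapiens) for inhibition, read by CCK-8 assay, with a stated time of 70 h (on this read-out lower numbers stand for stronger inhibition and higher numbers for weaker inhibition), so far:
Compound 1 `Nc1ccc(COc2ccc(OCCOCCNC3CCCC3)cc2)cc1` gives 31700 nM
Compound 2 `COC(=O)c1ccc(COc2ccc(OCCOCCNC3CCCC3)cc2)cc1` gives 6990 nM
Compound 3 `c1ccc(COc2ccc(OCCOCCNC3CCOC3)cc2)cc1` gives 48000 nM

Among these three, compound 2 has the lowest number, at 6990 nM, and the other two stand higher by more than the scatter. Compound 4 `O=C(O)c1ccc(COc2ccc(OCCOCCNC3CCCC3)cc2)cc1` departs from compound 2 in one place: hydrogen in place of methyl on an oxygen next to a carbonyl group, which turns methoxycarbonyl into carboxy.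

Within the data shown here, only one measured step touches this substituent. It runs a 4.5-fold lower number from compound 1 to compound 2 (0.66 log units; beyond the scatter), with methoxycarbonyl in place of amino, and it is modest but beyond the scatter. Among the measured compounds shown here, no measured compound carries carboxy, so this step offers a scale for the size of a change here and no direct guide to its direction. Compound 3 differs from the others elsewhere and does not bear on this change. Since compound 2 sits at the low end of the series, a modest move to a higher number in this assay is expected, though a result within the scatter remains possible.

The expected change is a 2.9-fold higher number from compound 2 to compound 4 (0.46 log units; beyond the scatter) on this estimate. For compound 4 the estimated value is 20000 nM, with an expected range from 7000 nM to 60000 nM in this read-out.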

Compound 4, half-maximal inhibitory concentration: > 100000 nM
Compound 4 was reported as a limit; the forecaster's own chance of this, stated with the estimate: 10%; middle value at least 5.0-fold (0.69 log units) from the limit.
By their numbers in this assay, from the lowest: compound 2; then compounds 1 and 3 (each within the scatter of the next). At a limit, above all of these: compound 4.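

Compound 4 is reported in this assay only as a limit, > 100000 nM: the limit of > 100000 nM in this assay, at which 1 of the 4 values shown sits.

Turning methoxycarbonyl into carboxy, an exchange of methyl for hydrogen that removes a single heavy atom, gives an at least 14-fold higher number from compound 2 to compound 4 (1.15 log units; beyond the scatter), a large step set against the modest one seen earlier at this substituent, a 4.5-fold lower number from compound 1 to compound 2 (0.66 log units; beyond the scatter). Carboxy also stands on the high side of amino, with an at least 3.1-fold higher number from compound 1 to compound 4 (0.49 log units; beyond the scatter), so the three groups on this aromatic carbon now fall in a clear order, from methoxycarbonyl at the lowest number through amino to carboxy at the highest, and the position proves far more sensitive to the choice of group than the earlier compounds showed.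

Going by these compounds, how far the true number of compound 4 lies beyond its limit stays open, so the full size of this step is unknown. The compounds shown also leave open whether the lower number belongs to methoxycarbonyl in particular or extends to related groups on the same carbon, which a longer ester such as ethoxycarbonyl or a primary amide such as carbamoyl would help to separate.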